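Thiophene in Place of Fluorophenyl on the Shared Core

The compounds below may be only part of what the source reports. "The series", "measured", "known", "first", "only" and "open" are said of these compounds alone.

Of the compounds shown here, three built on the shared core have been measured in an assay on CFBE41o cells for positive allosteric modulation of Cystic fibrosis transmembrane conductance regulator variant F508del (Homo sapiens), with stated times of 30 min and 24 h; on this read-out higher numbers stand for an effect only at larger amounts of compound and lower numbers for an effect already at smaller amounts. Compound 1 `CSc1cccc(Nc2nc(-c3ccc(C#N)cc3)cs2)c1` gives 34000 nM, compound 2 `CSc1cccc(Nc2nc(-c3ccc(F)cc3)cs2)c1` gives 27000 nM, and compound 3 `CSc1cccc(Nc2nc(-c3ccc4[nH]c(=O)oc4c3)cs2)c1` gives 6400 nM. Compound 2 stands second highest of the three numbers; its nearest neighbour is compound 1, and the step of a 1.3-fold lower number from compound 1 to compound 2 (0.10 log units; within the scatter), fluoro in place of cyano on an aromatic carbon, shows no movement beyond the scatter. Among the compounds with values here, compound 3 sits furthest away, and the values of compound 2 and compound 3 differ by more than the scatter, but no single-site step connects them.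

Compound 4 `CSc1cccc(Nc2nc(-c3cccs3)cs2)c1` has not yet been measured. Its change from compound 2 is thiophen-2-yl in place of 4-fluorophenyl on an aromatic carbon. Within the data shown here, the only measured step that touches the same place is a 1.3-fold lower number from compound 1 to compound 2 (0.10 log units; within the scatter), and it stayed within the scatter. Among the measured compounds shown here, no measured compound carries a five-membered aromatic ring at this place, so the data give little to go on; the one related step points to a small effect. Compound 4 is therefore expected to show a step of about a 1.1-fold lower number from compound 2 to compound 4 (0.03 log units; within the scatter) in this assay, not beyond the scatter. Compound 4 is estimated at 25000 nM, within the range from 8000 nM to 80000 nM.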

Compound 4, half-maximal effective concentration: "not active" (no number reported)
No number was reported for compound 4; there is nothing to compare the estimate with.
By their numbers in this assay, from the lowest: compound 3; then compounds 2 and 1 (each within the scatter of the next).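

In this assay, within the data shown here, compound 4 gives "not active" (no number reported), so no step from compound 2 to compound 4 can be read. Nothing at hand offers an explanation for this result. The compounds shown leave open how large an effect thiophen-2-yl in place of 4-fluorophenyl has on this read-out.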